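The compounds below may be only part of what the source reports. "The series", "measured", "known", "first", "only" and "open" are said of these compounds alone.

The shared core of this small series is shown by compound 1 `COC1=C(C)C(=O)/C(=C(O)/C=C/c2ccc(O)cc2)C(=O)C1(C)C`, which carries a 4-hydroxyphenyl group on a double-bonded chain carbon. In a functional assay on PC-3 cells (Homo sapiens) for cytotoxicity (on this read-out higher numbers stand for an effect only at larger amounts of compound and lower numbers for an effect already at smaller amounts), compound 1 gives only a limit, > 20 ug/mL, the edge of what the measurement reports (the limit of > 20 ug/mL in this assay, at which 1 of the 3 values shown sits). Compound 2 `CCc1ccc(/C=C/C(O)=C2/C(=O)C(C)=C(OC)C(C)(C)C2=O)cc1` keeps the core and has ethyl in place of hydroxy on an aromatic carbon; in this assay compound 2 gives 15.1 ug/mL. Compound 3 `C=Cc1ccccc1/C=C/C(O)=C1/C(=O)C(C)=C(OC)C(C)(C)C1=O` carries 2-vinylphenyl instead; in this assay compound 3 gives 4.6 ug/mL. The steps are an at least 1.3-fold lower number from compound 1 to compound 2 (0.12 log units; that floor lies within the scatter), an at least 4.3-fold lower number from compound 1 to compound 3 (0.63 log units; beyond the scatter) and a 3.3-fold lower number from compound 2 to compound 3 (0.52 log units; beyond the scatter).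

Compound 4 `COC1=C(C)C(=O)/C(=C(O)/C=C/c2nccs2)C(=O)C1(C)C` has not yet been measured. It differs from compound 1 in one place: 1,3-thiazol-2-yl in place of 4-hydroxyphenyl on a double-bonded chain carbon bound to a double-bonded chain carbon. Among the measured compounds shown here, two measured steps bear on this change, since both exchange the 4-hydroxyphenyl of compound 1 for another aromatic group at the same place: an at least 1.3-fold lower number from compound 1 to compound 2 (0.12 log units; that floor lies within the scatter) and an at least 4.3-fold lower number from compound 1 to compound 3 (0.63 log units; beyond the scatter). Both move the number downward, and the second does so beyond the scatter. A downward step of modest size is therefore expected, an at least 1.6-fold lower number from compound 1 to compound 4 (0.22 log units; that floor lies within the scatter). Compound 4 is estimated at 12 ug/mL in this assay, with a range from 4 ug/mL to 30 ug/mL.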

Compound 4, concentration for half-maximal effect: 10.8 ug/mL
Estimate against measurement, compound 4: 1.1-fold (0.05 log units) above, and the stated range covers the measured number.
By their numbers in this assay, from the lowest: compound 3; then compounds 4 and 2 (each within the scatter of the next). At a limit, above all of these: compound 1.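

Compound 4 shows that the place on a double-bonded chain carbon bound to a double-bonded chain carbon does not need a six-membered carbon ring: in this assay, 1,3-thiazol-2-yl, a five-membered aromatic ring with 2 hetero atoms, gives a 1.4-fold lower number from compound 2 to compound 4 (0.15 log units; within the scatter), so it cannot be told apart from the 4-ethylphenyl of compound 2. The 2-vinylphenyl group still stands apart, with a 2.3-fold higher number from compound 3 to compound 4 (0.37 log units; beyond the scatter), which leaves compound 3 with the lowest number of the four. Exchanging the 4-hydroxyphenyl gives an at least 1.8-fold lower number from compound 1 to compound 4 (0.26 log units; that floor lies within the scatter), and this is only a floor, since compound 1 stands at a limit rather than at a number: the limit of > 20 ug/mL in this assay, at which 1 of the 4 values shown sits.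

The compounds shown leave open how a pyridine ring, or an amine or a carboxylic acid on the aromatic ring, would read at this place. They also do not separate the nitrogen from the sulfur of the 1,3-thiazol-2-yl, which a thiophene ring or an oxazole ring at the same place could do.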